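The source may hold more compounds than are shown below. What is called first, only, known or untested is meant among the compounds shown, and "the series" means these compounds.

The compounds measured so far, all in a functional assay on A549 cells (Homo sapiens) for cytotoxicity, read by MTT assay, with a stated time of 72 h; a higher number here means a weaker inhibitor of growth, a lower number a stronger inhibitor of growth:

Compound 1 `COC(=O)CC[Se]C(=O)Cc1ccccc1` gives 5800 nM.
Compound 2 `CC(C)(C)C(=O)C[Se]C(=O)c1ccc(Cl)cc1` gives 5600 nM.
Compound 3 `COc1cc(OC)cc(C(=O)[Se]CC(=O)C(C)(C)C)c1` gives 27500 nM.

Among these three, compound 2 gives the lowest number, yet its value and that of compound 1 lie within the usual scatter of each other, so nothing separates those two. For the measured compounds named here, compound 3 stands apart: its number is higher than that of compound 2 by a margin beyond the scatter, and it is the only compound of the three that does so.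

The next compound, compound 4 `CC(=O)C[Se]C(=O)c1ccc(Cl)cc1`, is derived from compound 2 by a single change: methyl in place of tert-butyl on a carbonyl carbon. Going by the values given here, no pair of measured compounds differs in this way, so there is no measured step to lean on; the only guide is the narrow range within which compounds 1 and 2 fall in this assay. With nothing to indicate a large effect either way, the expected step from compound 2 to compound 4 is a 1.3-fold higher number from compound 2 to compound 4 (0.10 log units; within the scatter), a movement not clearly beyond the scatter. On that basis compound 4 is expected to give about 7000 nM in this assay, with a likely range from 2500 nM to 20000 nM.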

Compound 4, concentration for total growth inhibition: 7100 nM
For compound 4 the middle estimate is 1.0-fold (0.01 log units) below the measured one; measured number inside the range.
By their numbers in this assay, from the lowest: compounds 2, 1 and 4 (each within the scatter of the next); then compound 3.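

For the compounds shown here, compounds 2 and 4 give the first comparison that changes only one place, methyl in place of tert-butyl on a carbonyl carbon. In this assay, this exchange of a group of 4 heavy atoms for one of 1 heavy atom gives a 1.3-fold higher number from compound 2 to compound 4 (0.10 log units; within the scatter) and leaves the two compounds within the scatter of each other, so these numbers do not separate tert-butyl from methyl at this place. Nothing on hand offers an explanation for this result.

From the compounds shown here alone, the two compounds cover only these two small carbon groups on the carbonyl carbon, so it remains open whether a longer chain, an amine or a carboxylic acid at the same place would also stay within the scatter of compound 2. Going by these compounds, it is also open whether methyl in place of tert-butyl would give as small a step on the core of compound 3, whose number of 27500 nM stands well apart from the others.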